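The source may report more compounds than this note shows. Statements on the series, on what has been measured and on what is new or still open speak of the compounds shown alone.

Working notes on the series, read in a functional assay on ECa-109 cells for inhibition, with ECa-109 cell line (Homo sapiens) as the target, read by sulforhodamine B assay; on this read-out higher numbers stand for weaker inhibition and lower numbers for stronger inhibition. Three members with different aryl groups on the amine nitrogen of the shared core have been measured. Compound 1 `CCCc1ccc(NC2=CC(=O)c3nc4n(c3C2=O)[C@H]2OC[C@@H](O)[C@H]2OC4)cc1`, the 4-propylphenyl member, gives > 4000 nM, which is a limit of the assay. Compound 2 `O=C1C=C(Nc2ccccc2F)C(=O)c2c1nc1n2[C@H]2OC[C@@H](O)[C@H]2OC1`, the 2-fluorophenyl member, gives 2760 nM. Compound 3 `COc1ccccc1NC1=CC(=O)c2nc3n(c2C1=O)[C@H]1OC[C@@H](O)[C@H]1OC3`, the 2-methoxyphenyl member, gives > 4000 nM, which is also a limit of the assay. Compound 3 therefore has no number of its own and stands with compound 1 at the limit of > 4000 nM in this assay, at which 2 of the 3 values shown sit.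

Compound 4 `COc1ccc(NC2=CC(=O)c3nc4n(c3C2=O)[C@H]2OC[C@@H](O)[C@H]2OC4)cc1` differs from compound 3 by 4-methoxyphenyl in place of 2-methoxyphenyl on an amine nitrogen.

Among the compounds with values here, no measured step makes this exact exchange, so the support is indirect. The measured steps are an at least 1.4-fold lower number from compound 1 to compound 2 (0.16 log units; that floor lies within the scatter), an at least 1.4-fold higher number from compound 2 to compound 3 (0.16 log units; that floor lies within the scatter) and a step that the two limits leave unreadable from compound 1 to compound 3. None of them shows a change beyond the scatter, so no step beyond the scatter is expected in this assay. The expected outcome is a number no higher from compound 3 to compound 4 (the limit leaves the size open), and a second limit reading would not be surprising. For compound 4 the estimated value is 4000 nM, within an expected range of 1800 nM to 9000 nM.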

Compound 4, half-maximal inhibitory concentration: > 4000 nM
Compound 4 was reported as a limit; the forecaster's own chance of this, stated with the estimate: 55%; the middle value sits exactly at the limit.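

In this assay compound 4, the 4-methoxyphenyl member, gives > 4000 nM, which is a limit of the assay. Within the data shown here, the only readable step is an at least 1.4-fold higher number from compound 2 to compound 4 (0.16 log units; that floor lies within the scatter), so even here the data show no change beyond the scatter; the steps to compound 4 from compound 1 and from compound 3 cannot be read, as both ends of each are limits. Exchanging 2-methoxyphenyl for 4-methoxyphenyl on the amine nitrogen therefore yields no measurable value at either placement of the methoxy group, and the series now gathers at a single reading: the limit of > 4000 nM in this assay, at which 3 of the 4 values shown sit.

Among these compounds, how far compound 1, compound 3 and compound 4 lie beyond that limit stays unknown, so no order among the three can be stated, and compound 2 remains the only member with a number of its own. Also open, on these data alone, is whether the reading of compound 2 is tied to the fluoro group and its placement, which 4-fluorophenyl on the same amine nitrogen would test, and whether a basic amine or a carboxylic acid on the aryl ring would give a value at all.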